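The source may hold more compounds than are shown below. What is called first, only, known or untested is meant among the compounds shown, and "the series" means these compounds.

Compound 2 `CN(C)CCn1cnnc1-c1cc(Oc2ccc(NC(=O)N/N=C/c3ccc(F)cc3)cc2F)ccn1` is one of two closely related ureas tested in a functional assay on U-87MG ATCC cells (Homo sapiens) for cytotoxicity, read by MTT assay, with a stated time of 72 h (a lower number here means a stronger inhibitor, a higher number a weaker inhibitor), and in that test compound 2 gives 2310 nM. Its companion, compound 1 `CN(C)CCn1cnnc1-c1cc(Oc2ccc(NC(=O)N/N=C/c3ccc(Cl)cc3Cl)cc2F)ccn1`, gives 2330 nM in this assay. Among the measured compounds shown here, the one measured step between them, a 1.0-fold lower number from compound 1 to compound 2 (0.00 log units; within the scatter), shows that swapping the aryl group on the carbon with a double bond to nitrogen left the read-out essentially unchanged. Compound 2 therefore holds the lowest of the two numbers seen, with compound 1 sitting within the scatter of it, so neither can be called the stronger inhibitor.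

Compound 3 `COc1cc(/C=N/NC(=O)Nc2ccc(Oc3ccnc(-c4nncn4CCN(C)C)c3)c(F)c2)cc(OC)c1OC` is not yet measured. It differs from compound 2 in one place: 3,4,5-trimethoxyphenyl in place of 4-fluorophenyl on a carbon with a double bond to nitrogen. For the measured compounds named here, the only measured step that bears on this change is a 1.0-fold lower number from compound 1 to compound 2 (0.00 log units; within the scatter), which altered the same aryl group and produced no shift beyond the scatter. On that basis compound 3 is expected to give a number close to that of compound 2, with the step of a 1.0-fold lower number from compound 2 to compound 3 (0.00 log units; within the scatter) expected to stay within the scatter. The estimate for compound 3 is 2300 nM, with a range from 900 nM to 6000 nM.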

Compound 3, half-maximal inhibitory concentration: 22500 nM
Compound 3: the middle estimate sits 9.8-fold (0.99 log units) below what was measured; measured number outside the range, above it.
By their numbers in this assay, from the lowest: compounds 2 and 1 (each within the scatter of the next); then compound 3.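

In this assay, the aryl group on the carbon with a double bond to nitrogen can clearly move the read-out: there is a 9.7-fold higher number from compound 2 to compound 3 (0.99 log units; beyond the scatter) and also a 9.7-fold higher number from compound 1 to compound 3 (0.98 log units; beyond the scatter) when 3,4,5-trimethoxyphenyl enters. Among the compounds shown here, the earlier swap between 2,4-dichlorophenyl and 4-fluorophenyl therefore did not show that this position tolerates any aryl group, only that these two groups read alike, and compound 3 is the weaker inhibitor against both. The entering group has 12 heavy atoms and 3 hydrogen-bond acceptors, against 7 heavy atoms and 0 hydrogen-bond acceptors for 4-fluorophenyl, but nothing measured here connects either difference to the shift.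

The compounds shown leave open whether a single methoxy group on the phenyl ring would already raise the number or whether the full set of three is needed for a shift of this size. They also leave open how a phenyl ring carrying an amine or a carboxylic acid would read at this position, so the limits of what the position accepts remain undefined.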